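This account rests on a few compounds, and the source may have more. Where it says the series, first, only, none or still open, it means among the compounds named here.

The study concerns a small set of purine-like compounds bearing a chloromethylbenzyl group, examined in a functional assay on COLO 205 cells (Homo sapiens) for cytotoxicity, read by sulforhodamine B assay, with a stated time of 48 h; a higher number here means a weaker inhibitor of growth, a lower number a stronger inhibitor of growth. Compound 1 `ClCc1ccc(Cn2cnc3c(Cl)ncnc32)cc1` carries the chloromethyl group in the para position of the benzyl ring. In this assay compound 1 gives > 100000 nM, which is a limit of the assay rather than a number. Compound 2 `ClCc1ccc(Cn2cnc3nc(Cl)nc(Cl)c32)cc1` is its dichloro counterpart. Compound 2 also gives > 100000 nM, again a limit. Compound 3 `ClCc1ccccc1Cn1cnc2ncnc(Cl)c21` moves the chloromethyl group to the ortho position of the benzyl ring. Compound 3 gives > 100000 nM, likewise a limit and not a measured number. Compound 3 thus stands with the other two at the same boundary, as described by the limit of > 100000 nM in this assay, at which 3 of the 3 values shown sit, so nothing separates the three on the values shown.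

Compound 4 `ClCc1ccccc1Cn1cnc2nc(Cl)nc(Cl)c21` is the unmeasured analogue of compound 3. The change is chloro in place of hydrogen on an aromatic carbon. The pair of compound 1 and compound 2 shows the same kind of change, and both sit at the limit, so no size of step can be read from them. No step beyond the scatter is expected in this assay in either direction. Compound 4 is therefore expected to give 100000 nM, with a plausible range from 30000 nM to 300000 nM, most likely reported only as a limit. The expected step from compound 3 to compound 4 is a number no higher from compound 3 to compound 4 (the limit leaves the size open).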

Compound 4, concentration for total growth inhibition: > 100000 nM
Compound 4: a limit, no number; the forecaster's own chance of this, stated with the estimate: 85%; the middle value sits exactly at the limit.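

No new step can be read from compound 3 to compound 4, since both give a limit and not a number: the limit of > 100000 nM in this assay, at which 4 of the 4 values shown sit.

The compounds shown leave open whether chloro in place of hydrogen on an aromatic carbon changes growth inhibition at all, and what, if anything, separates these four compounds.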